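Chloro substitution on the aryl ether arm of the series

The source may hold more compounds than are shown below. What is called first, only, known or untested is meant among the compounds shown, and "the series" means these compounds.

Measured compounds:
compound 1 `COc1cccc([C@@H](CO)O[C@H]2CCCN(Cc3ccc(C(=O)O)cc3C)[C@H]2c2ccccc2)c1`: 81000 nM
compound 2 `Cc1cc(C(=O)O)ccc1CN1CCC[C@H](O[C@H](CO)c2cc(Cl)nc(Cl)c2)[C@@H]1c1ccccc1`: 2400 nM
compound 3 `Cc1cc(C(=O)O)ccc1CN1CCC[C@H](O[C@H](CO)c2ccnc(Cl)c2)[C@@H]1c1ccccc1`: 50000 nM

In an assay on isolated protein for activation of cGMP-dependent protein kinase 1 (Homo sapiens), read by ADP-Glo, with stated times of 30 min and 2 h, in the presence of a further agent that is not named here (on this read-out higher numbers stand for an effect only at larger amounts of compound and lower numbers for an effect already at smaller amounts), compound 3 gives 50000 nM, the second highest of the three numbers. Its nearest neighbour is compound 1, with a gap of a 1.6-fold lower number from compound 1 to compound 3 (0.21 log units; within the scatter), which is within the scatter. Going by the values given here, the one well separated compound is compound 2, and the step of a 21-fold higher number from compound 2 to compound 3 (1.32 log units; beyond the scatter) is large and beyond the scatter.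

Compound 4 `Cc1cc(C(=O)O)ccc1CN1CCC[C@H](OC(c2cc(Cl)cc(Cl)c2)C(C)O)[C@@H]1c1ccccc1` carries the change (a group of 12 heavy atoms (9 carbon, 1 oxygen, 2 chlorine; one six-membered aromatic ring of carbon only) in place of a group of 10 heavy atoms (7 carbon, 1 nitrogen, 1 oxygen, 1 chlorine; one six-membered aromatic ring with 1 hetero atom), on an oxygen on a saturated carbon). Among the compounds with values here, two measured steps bear on it. The step of a 34-fold lower number from compound 1 to compound 2 (1.53 log units; beyond the scatter) shows that a ring carrying two chloro groups gave a much lower number than the methoxy-bearing ring, and the step of a 21-fold higher number from compound 2 to compound 3 (1.32 log units; beyond the scatter) shows that taking one chloro away brought the number most of the way back up. Compound 4 restores a second chloro group, although on an all-carbon ring and with a longer chain that now carries a methyl and has no defined stereocentre. On that basis a clearly lower number than compound 3 is expected in this assay, though the uncertainty from the altered ring and chain is considerable, so the expected step for compound 4 is a 6.3-fold lower number from compound 3 to compound 4 (0.80 log units; beyond the scatter). Compound 4 is estimated at 8000 nM, with a range from 1500 nM to 45000 nM.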

Compound 4, half-maximal effective concentration: 5300 nM
The estimate for compound 4 lay 1.5-fold (0.18 log units) above the measured number; measured number inside the range.
By their numbers in this assay, from the lowest: compound 2; then compound 4; then compounds 3 and 1 (each within the scatter of the next).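

In this assay, a low number at this position does not depend on the ring nitrogen: the entering all-carbon aromatic ring with 2 chlorine atoms gives a 9.4-fold lower number from compound 3 to compound 4 (0.97 log units; beyond the scatter) and a 15-fold lower number from compound 1 to compound 4 (1.18 log units; beyond the scatter). Compound 2 still keeps a lower number, with a 2.2-fold higher number from compound 2 to compound 4 (0.34 log units; beyond the scatter), so among these compounds the two groups with 2 chlorine atoms both lie below the groups of compound 3 and compound 1, while the replacement of the ring with 1 hetero atom by the all-carbon one, made together with the chain change, comes with a modest rise. No measurement shown here offers an explanation for these steps.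

The group on the oxygen changes its ring and its chain together and also loses the defined stereocentre, so the share of each in these steps remains unresolved, and the separate stereoisomers of compound 4 remain an open comparison. Also open, from the compounds shown here alone, is whether bromo or trifluoromethyl in place of chloro, or a longer chain carrying the hydroxyl, would hold or lower the number on the shared core.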